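Swapping the acid chain for benzyl: expected cytotoxicity

The source may report more compounds than this note shows. Statements on the series, on what has been measured and on what is new or still open speak of the compounds shown alone.

Measured compounds:
compound 1, `CC[C@@H]1CC2(C[C@@H](CC)N1)C(=O)NC(=O)N2Cc1ccccc1`: > 100 uM
compound 2, `COC(=O)C1=C(c2ccccn2)N(Cc2ccc(Cl)cc2)C(c2ccccn2)CC1=O`: "not determined" (no result reported)
compound 3, `COC(=O)C1C(=O)C(C(=O)OC)[C@H](c2ccccn2)N(CCCC(=O)O)[C@@H]1c1ccccn1`: 46 uM

The readout is an ADME assay on J774.1 cells (Mus musculus) for cytotoxicity, with a stated time of 48 h; a higher number here means that more compound is needed for the effect, a lower number that less compound is needed. For compound 1 the result is a limit of the assay, not a number, (the limit of > 100 uM in this assay, at which 1 of the 3 values shown sits). For compound 2 no result is reported in this assay. Compound 3 therefore holds the only number shown, at 46 uM. Of the other two entries, one is the limit of compound 1 and one is the entry without a number for compound 2.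

The unmeasured compound is compound 4, `COC(=O)C1C(=O)C(C(=O)OC)[C@H](c2ccccn2)N(Cc2ccccc2)[C@@H]1c1ccccn1`. It differs from compound 3 in one place, (phenyl in place of 2-carboxyethyl on a saturated chain carbon bound to an amine nitrogen in a ring). For the measured compounds named here, no step between two measured compounds with a single number is available, so no measured step points the way. Compound 4 is expected to need somewhat less compound than compound 3, a step of a 1.8-fold lower number from compound 3 to compound 4 (0.26 log units; within the scatter), not far beyond the usual scatter. The estimate for compound 4 in this assay is 25 uM, with a range from 8 uM to 90 uM.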

Compound 4, concentration for half-maximal effect: 34 uM
Compound 4: middle estimate off by 1.4-fold (0.13 log units), on the low side, and the stated range covers the measured number.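

Replacing 2-carboxyethyl with phenyl on a saturated chain carbon bound to an amine nitrogen in a ring gives a 1.4-fold lower number from compound 3 to compound 4 (0.13 log units; within the scatter) in this assay, so this read-out does not separate the two groups. Compound 4 carries no carboxylic acid and still gives a number, which shows that the acid is not required for cytotoxicity on this shared core. Neither compound of this pair reaches a limit of the assay, a form of result held here by compound 1 alone: the limit of > 100 uM in this assay, at which 1 of the 4 values shown sits.

On these data alone, what an amine or a longer chain at this place would do to the number stays open. As far as these compounds go, with a single step in hand, it also stays open whether 3-carboxypropyl and benzyl would remain this close on another core.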